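Sulfonyl cap variation in a piperidine hydroxamate series

This account rests on a few compounds, and the source may have more. Where it says the series, first, only, none or still open, it means among the compounds named here.

For the measured compounds named here, in a functional assay on HCT-116 cells (Homo sapiens) for inhibition, read by resazurin assay, with a stated time of 5 days (a lower number here means a stronger inhibitor of growth, a higher number a weaker inhibitor of growth), compound 2 `O=C(CCCC1CCN(S(=O)(=O)Nc2ccccc2)CC1)NO` gives 2000 nM, the lowest of the two numbers measured so far. Its nearest neighbour, compound 1 `Cc1cc(S(=O)(=O)N2CCC(CCCC(=O)NO)CC2)cc2ccccc12`, gives 17300 nM in this assay, a gap that lies beyond the usual scatter. Compound 3 `O=C(CCCC1CCN(S(=O)(=O)c2ccc3c(c2)OCCO3)CC1)NO` gives "not determined" (no result reported) in this assay, so no number is reported for it. Compound 4 `O=C(CCCC1CCN(S(=O)(=O)c2ccccc2)CC1)NO` differs from compound 2 by phenyl in place of anilino on a sulfonyl sulfur. Going by the values given here, no measured pair shows this single change, so its size and direction rest on no direct precedent. The step from compound 2 to compound 4 is expected to be a modest loss, a 2.0-fold higher number from compound 2 to compound 4 (0.30 log units; within the scatter), close to the edge of the scatter rather than clearly beyond it. Compound 4 is therefore estimated at 4000 nM, with a plausible range from 1500 nM to 12000 nM.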

Compound 4, concentration for 50% growth inhibition: 2700 nM
For compound 4 the middle estimate is 1.5-fold (0.17 log units) above the measured one; measured number inside the range.
By their numbers in this assay, from the lowest: compounds 2 and 4 (each within the scatter of the next); then compound 1.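

Phenyl in place of anilino on a sulfonyl sulfur gives a 1.4-fold higher number from compound 2 to compound 4 (0.13 log units; within the scatter) in this assay, the first single-place comparison in the series. At this position, the hydrogen-bond donor counted on anilino and absent from phenyl therefore goes with no separation between compound 2 and compound 4, a reading that rests on this one pair. No available evidence bears on this result.

Going by these compounds, whether a benzylamino or pyridyl group on the sulfonyl sulfur would fall within the scatter of compound 2 and compound 4 remains open. On these data alone, the effect of a longer chain carrying the hydroxamate is also open.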